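From isopropyl to dimethylamino on a sulfonyl sulfur

The source may hold more compounds than are shown below. What is called first, only, known or untested is meant among the compounds shown, and "the series" means these compounds.

Compound 1 `C=CC(=O)Nc1cc(Nc2ncc(F)c(Nc3ccccc3S(=O)(=O)N(C)C)n2)c(OC)cc1N(C)CCN(C)C` gives 7% as its measured value
Compound 2 `C=CC(=O)Nc1cc(Nc2ncc(Cl)c(Nc3ccccc3S(=O)(=O)C(C)C)n2)c(OC)cc1N(C)CCN(C)C` gives 11% as its measured value

Both numbers come from an ADME assay on microsomes from liver (Rattus norvegicus) for metabolic stability, read by LC-MS, using NADPH, with a stated time of 30 min, tested at 1 uM (a lower number here means that less of the compound is left, a higher number that more of the compound is left), and lie within the usual scatter of each other, so compound 2 stands level with compound 1 on the two values available. Little of either compound is left at the end of the incubation.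

The next structure is compound 3 `C=CC(=O)Nc1cc(Nc2ncc(Cl)c(Nc3ccccc3S(=O)(=O)N(C)C)n2)c(OC)cc1N(C)CCN(C)C` which has not yet been measured. Compared with compound 2 it has dimethylamino in place of isopropyl on a sulfonyl sulfur and nothing else in the structure changes.

Within the data shown here, no pair of measured compounds differing in one place is available, so the data hold no direct precedent for the size of this step. Among the measured compounds shown here, the only guide is that both measured compounds sit close together near the bottom of the scale in this assay and a value in that region is therefore expected. The expected change is a number 2 percentage points lower from compound 2 to compound 3 (within the scatter) and this estimated step is not expected to go beyond the scatter. For compound 3 the estimated value is 9% with an expected range from 3% to 20% in this measurement.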

Compound 3, percent of the compound remaining: 13%
Estimate against measurement, compound 3: 4 percentage points below; the range from low to high includes it.
By their numbers in this assay, from the lowest: compounds 1, 2 and 3 (each within the scatter of the next).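

Among these compounds, putting dimethylamino in place of isopropyl on a sulfonyl sulfur gives, in this assay, a number 2 percentage points higher from compound 2 to compound 3 (within the scatter), the first reading at this position with only one place changed, and it leaves the two groups level in this measurement. Compound 3 also links the two earlier compounds, which differed in two places: chloro in place of fluoro on an aromatic carbon gives a number 6 percentage points higher from compound 1 to compound 3 (within the scatter), so this change, read alone, also stays within the usual scatter. Nothing measured alongside these values bears on why the compounds stand level.

Open, on these data alone, is whether a larger group on the same sulfonyl sulfur, such as morpholine or piperidine, or a bromo or trifluoromethyl in place of chloro on that aromatic carbon, would give a step beyond the scatter. Each change has also been read against only one background, so the compounds shown cannot tell whether isopropyl and dimethylamino would stand level with fluoro in place of chloro, or whether either change would behave the same way on a different shared core.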